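Chalcone-pyrazole hybrids: halogen swap on the aryl ketone

The source may report more compounds than this note shows. Statements on the series, on what has been measured and on what is new or still open speak of the compounds shown alone.

Compound 1 `COc1ccc(-c2cc(/C=C/C(=O)c3ccc(OC)c(OC)c3)[nH]n2)cc1`: 85%
Compound 2 `COc1cc(-c2cc(/C=C/C(=O)c3ccc(Cl)c(Cl)c3)[nH]n2)cc(OC)c1OC`: 96%

Both compounds were tested in a functional assay on UACC-62 cells (Homo sapiens) for cytotoxicity, read by sulforhodamine B assay, with a stated time of 48 h, tested at 1 uM; a lower number here means a stronger effect, a higher number a weaker effect of the compound at the concentration tested. Of the two numbers, compound 2 stands highest with 96%, and compound 1 gives 85%, a value that lies beyond the scatter below it. Compound 3 `COc1cc(-c2cc(/C=C/C(=O)c3ccc(F)c(F)c3)[nH]n2)cc(OC)c1OC` has not yet been measured. It differs from compound 2 by 3,4-difluorophenyl in place of 3,4-dichlorophenyl on a carbonyl carbon. Among the compounds with values here, no step between two measured compounds shows the effect of this exchange, so the expectation rests on compound 2 alone; the step from compound 2 to compound 3 in this assay is estimated to be small and within the scatter, a number 3 percentage points lower from compound 2 to compound 3 (within the scatter). For compound 3 the expected value is 93%, with a range from 80% to 105%.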

Compound 3, a percentage reported as activity, at one concentration (the size of the read-out at that concentration, not a potency): 88%
Beside the measured number, compound 3's estimate is 5 percentage points above it; the measured number falls inside the stated range.
By their numbers in this assay, from the lowest: compounds 1, 3 and 2 (each within the scatter of the next, the first and the last beyond it).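

Within the data shown here, compound 2 and compound 3 form the first pair that isolates this position, and in this assay the exchange of 3,4-dichlorophenyl for 3,4-difluorophenyl on a carbonyl carbon gives a number 8 percentage points lower from compound 2 to compound 3 (within the scatter). The two halogen pairs therefore cannot be told apart in this read-out. No measurement shown here accounts for this step. On these data alone, what remains open is what an aminophenyl or a carboxyphenyl group would give on the same carbonyl carbon, and whether any group placed there separates clearly from these two.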